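Two halogens, one limit: estimating compound 4

A few compounds are considered here, and "the series" means these few. Any claim that something is new, unique, unknown or untested is made for them only; others in the source may bear on it.

Measured in a functional assay on K562 cells (Homo sapiens) for inhibition, read by trypan blue exclusion, with a stated time of 48 h; a lower number here means a stronger inhibitor, a higher number a weaker inhibitor:
Compound 1 `NC(=O)c1cc(Cl)ccc1NC(=O)/C=C/c1ccccc1Br`: 10000 nM
Compound 2 `NC(=O)c1cc(Br)ccc1NC(=O)/C=C/c1ccccc1Cl`: 8100 nM
Compound 3 `NC(=O)c1cc(Br)ccc1NC(=O)/C=C/c1ccc(Cl)cc1`: > 10000 nM, a limit of the assay

Compound 3 has no exact number, only (the limit of > 10000 nM in this assay, at which 1 of the 3 values shown sits). Its true place among these compounds is therefore unknown.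

Compound 4 `NC(=O)c1cc(Br)ccc1NC(=O)/C=C/c1ccccc1Br` has 2-bromophenyl in place of 4-chlorophenyl on a double-bonded chain carbon bound to a double-bonded chain carbon.

For the measured compounds named here, one measured step bears most directly on this change: an at least 1.2-fold higher number from compound 2 to compound 3 (0.09 log units; that floor lies within the scatter). There, 4-chlorophenyl replaces 2-chlorophenyl, so the step to compound 4 runs the opposite way, but with bromine in the group that enters. Compound 1, which also carries 2-bromophenyl, gives 10000 nM, and compound 2 gives 8100 nM. Those two values lie within the scatter of each other.

A modest move toward a lower number is therefore expected in this assay, perhaps none beyond the scatter. The expected change is an at least 1.1-fold lower number from compound 3 to compound 4 (0.04 log units; that floor lies within the scatter). The estimated value for compound 4 is 9000 nM. The expected range runs from 5500 nM to 14000 nM.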

Compound 4, half-maximal inhibitory concentration: > 10000 nM
Compound 4: only a limit was reported (the forecaster's own chance of this, stated with the estimate: 35%); middle value at least 1.1-fold (0.04 log units) away from the limit.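

In this assay compound 4 gives > 10000 nM as a limit of the assay, not as an exact number. Bromo in place of chloro on an aromatic carbon gives an at least 1.2-fold higher number from compound 2 to compound 4 (0.09 log units; that floor lies within the scatter) and so shows no change that can be told apart from the scatter, although the true size of the step stays open. The same replacement on another aromatic carbon gives a number no lower from compound 1 to compound 4 (the limit leaves the size open). With bromo kept on the shared core, 2-bromophenyl now joins 4-chlorophenyl at the limit, and of these three compounds only compound 2 has an exact value.

The step to compound 4 from compound 3 cannot be read, because the values stop at a ceiling: the limit of > 10000 nM in this assay, at which 2 of the 4 values shown sit. On these data alone, whether a methoxy group or an amine in place of the halogen on this phenyl group would give a readable value stays open.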